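The source may hold more compounds than are shown below. What is called first, only, known or untested is meant among the compounds shown, and "the series" means these compounds.

Measured compounds in an ADME assay on HEK293 cells (Homo sapiens) for inhibition, read by MTT assay, with stated times of 18 h and 4 h; a higher number here means a weaker inhibitor, a lower number a stronger inhibitor:
compound 1 `CCCCCCCCOP(=O)(O)OCCSC(=S)N1CCCCC1` — 69000 nM
compound 2 `CCCCCCCCOP(=O)(O)OCCSC(=S)N1CCN(C)CC1` — 86000 nM
compound 3 `CCCCCCOP(=O)(O)OCCSC(=S)N1CCCCC1` — a limit of this assay, not a number: > 100000 nM

Compound 1 and compound 2 differ in one place, (4-methylpiperazin-1-yl in place of piperidin-1-yl on a thiocarbonyl carbon), and that change gave a 1.2-fold higher number from compound 1 to compound 2 (0.10 log units; within the scatter). Compound 3 carries the core of compound 1 shortened by hydrogen in place of ethyl on a saturated chain carbon, six bonds along the chain from an oxygen on an unsaturated carbon, and the step of an at least 1.4-fold higher number from compound 1 to compound 3 (0.16 log units; that floor lies within the scatter) ends at a limit, since compound 3 reaches (the limit of > 100000 nM in this assay, at which 1 of the 3 values shown sits).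

Compound 4 `CCCCCCOP(=O)(O)OCCSC(=S)N1CCN(C)CC1` is not yet measured in this assay. It stands to compound 3 as compound 2 stands to compound 1: the change is 4-methylpiperazin-1-yl in place of piperidin-1-yl on a thiocarbonyl carbon, and the place is the same in both pairs, so it is the same change. In compound 1 to compound 2 that change moved the number only within the scatter, a 1.2-fold higher number from compound 1 to compound 2 (0.10 log units; within the scatter), and compound 3 already sits at the limit of this assay. Compound 4 is therefore expected to give a number near or beyond that limit, a step that the limit leaves unreadable from compound 3 to compound 4, most likely reported again as a limit. The estimate for compound 4 is 130000 nM, between 70000 nM and 300000 nM.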

Compound 4, half-maximal inhibitory concentration: > 100000 nM
Compound 4: only a limit was reported (the forecaster's own chance of this, stated with the estimate: 80%); the middle value does not contradict the limit.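

In this assay, the same shortening of the chain on the core of compound 2 gave an at least 1.1-fold higher number from compound 2 to compound 4 (0.06 log units; that floor lies within the scatter), while the step from compound 3 to compound 4 cannot be read. Both floors for this shortening lie within the scatter, so the compounds show no difference between the piperidin-1-yl and 4-methylpiperazin-1-yl cores, but they do not show that the change carries over with the same size: the same change on two cores in this assay, an at least 1.4-fold higher number (0.16 log units; that floor lies within the scatter) from compound 1 to compound 3 and an at least 1.1-fold higher number (0.06 log units; that floor lies within the scatter) from compound 2 to compound 4; the limit leaves it open whether they differ Nor can the two results show how far the shorter chain really moves the number on either core, or whether 4-methylpiperazin-1-yl in place of piperidin-1-yl does anything on the shorter chain, as compound 3 and compound 4 stand at the limit: the limit of > 100000 nM in this assay, at which 2 of the 4 values shown sit.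

The compounds shown leave open whether a longer chain would bring the numbers clearly inside the range of this assay on both cores. They also leave open whether a morpholin-4-yl group on the thiocarbonyl carbon would give a step beyond the scatter.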